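Dihydropyridine with an Oxadiazole Side Chain: Amide for Methyl

The compounds below may be only part of what the source reports. "The series", "measured", "known", "first", "only" and "open" are said of these compounds alone.

Measured so far:
Compound 1 `COC(=O)C1=C(C)N=C(C)/C(=C(/O)OC)C1c1cccc(OCCO[N+](=O)[O-])c1` gives 440 nM in an assay on Cortex for displacement of a labelled ligand from Voltage-dependent L-type calcium channel subunit alpha-1D (Rattus norvegicus); a lower number here means a stronger inhibitor, a higher number a weaker inhibitor.
Compound 2 `COC(=O)C1=C(C)N=C(C)/C(=C(/O)OC)C1c1cccc(OCc2nonc2C)c1` gives 320 nM in this assay.

Compound 2 has the lowest of the two numbers shown, but its gap to compound 1 is within the scatter. Among the compounds with values here, the only measured step, a 1.4-fold lower number from compound 1 to compound 2 (0.14 log units; within the scatter), exchanged the whole side chain and stayed within the scatter. Compound 3 `COC(=O)C1=C(C)N=C(C)/C(=C(/O)OC)C1c1cccc(OCc2nonc2C(N)=O)c1` differs from compound 2 by carbamoyl in place of methyl on an aromatic carbon. Within the data shown here, no measured step bears directly on this change. The expected number for compound 3 is therefore 400 nM, with a range of 150 nM to 1200 nM, an estimated step of a 1.3-fold higher number from compound 2 to compound 3 (0.10 log units; within the scatter) that stays within the scatter.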

Compound 3, inhibition constant: 2300 nM
Compound 3: the middle estimate sits 5.8-fold (0.76 log units) below what was measured; the measured number lies above the stated range.
By their numbers in this assay, from the lowest: compounds 2 and 1 (each within the scatter of the next); then compound 3.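

In this assay, within the data shown here, this aromatic carbon of the side-chain ring proves sensitive to what it carries: carbamoyl in place of methyl gives a 7.2-fold higher number from compound 2 to compound 3 (0.86 log units; beyond the scatter), the first step here beyond the scatter. The carbamoyl side chain also falls behind the nitrooxy chain, with a 5.2-fold higher number from compound 1 to compound 3 (0.72 log units; beyond the scatter), whereas the methyl version stayed within the scatter of it. Nothing available explains this loss.

Still open, going by these compounds, is whether the loss is specific to carbamoyl or would extend to other groups on this carbon, such as a nitrile, a carboxylic acid or an ethyl group.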